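From a Hydroxyphenyl Urea to a Trifluoromethylphenyl Urea

A few compounds are considered here, and "the series" means these few. Any claim that something is new, unique, unknown or untested is made for them only; others in the source may bear on it.

Compound 1 `COc1cc(NC(C)CCCNC(=O)Nc2ccc(O)cc2)c2ncccc2c1` was tested in a functional assay on MOLT-4 cells (Homo sapiens) for inhibition, read by MTT assay, with a stated time of 72 h (a higher number here means a weaker inhibitor, a lower number a stronger inhibitor), where compound 1 gives 21000 nM. Within the data shown here, this is the lowest of the two numbers measured so far. The other compound, compound 2 `COc1cc(NC(C)CCCNC(=O)NNC(=O)Nc2ccc(O)cc2)c2ncccc2c1`, gives 104000 nM in this assay, and the step of a 5.0-fold higher number from compound 1 to compound 2 (0.69 log units; beyond the scatter) is modest. That step puts ((4-hydroxyphenyl)carbamoyl)amino in place of 4-hydroxyphenyl on an amide-type nitrogen, so the 4-hydroxyphenyl group itself is kept.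

Compound 3 `COc1cc(NC(C)CCCNC(=O)Nc2cccc(C(F)(F)F)c2)c2ncccc2c1` has not yet been measured. It differs from compound 1 in one place: 3-(trifluoromethyl)phenyl in place of 4-hydroxyphenyl on an amide-type nitrogen. No measured step exchanges this aryl group, so nothing shown tells how the phenyl substituent matters in this assay, and the expectation can only be cautious. Compound 3 is estimated at 12000 nM, within a range from 3500 nM to 40000 nM. That amounts to an expected step of a 1.8-fold lower number from compound 1 to compound 3 (0.24 log units; within the scatter), which may well stay within the scatter.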

Compound 3, half-maximal inhibitory concentration: 20000 nM
Beside the measured number, compound 3's estimate is 1.7-fold (0.22 log units) below it; measured number inside the range.
By their numbers in this assay, from the lowest: compounds 3 and 1 (each within the scatter of the next); then compound 2.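

In this assay, among these compounds, this is the first exchange of the aryl group on the amide-type nitrogen, and a 1.1-fold lower number from compound 1 to compound 3 (0.02 log units; within the scatter) shows that 3-(trifluoromethyl)phenyl and 4-hydroxyphenyl are not told apart here, even though the entering group carries no hydrogen-bond donor or acceptor by the count. The second step, a 5.2-fold lower number from compound 2 to compound 3 (0.72 log units; beyond the scatter), shows that an aryl group placed directly on this nitrogen again gives a lower number than the ((4-hydroxyphenyl)carbamoyl)amino group, whichever of the two aryl groups is present. No measured evidence accounts for either result.

From the compounds shown here alone, whether a plain phenyl group on this nitrogen would give a similar number remains open. So does the outcome for a phenyl group carrying an amine or a carboxylic acid.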